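A few compounds are considered here, and "the series" means these few. Any claim that something is new, unique, unknown or untested is made for them only; others in the source may bear on it.

- compound 1 `O=C(N/N=C/c1cccc(Br)c1)Nc1cc2c(Nc3ccc(F)c(Cl)c3)ncnc2cc1O[C@H]1CCOC1`: 10700 nM
- compound 2 `O=C(N/N=C/c1ccc([N+](=O)[O-])cc1)Nc1cc2c(Nc3ccc(F)c(Cl)c3)ncnc2cc1O[C@H]1CCOC1`: 31200 nM
- compound 3 `O=C(N/N=C/c1ccc(F)cc1Cl)Nc1cc2c(Nc3ccc(F)c(Cl)c3)ncnc2cc1O[C@H]1CCOC1`: 27200 nM

All three values come from a functional assay on A549 cells (Homo sapiens) for cytotoxicity, read by MTT assay, with a stated time of 72 h; a higher number here means a weaker inhibitor, a lower number a stronger inhibitor. Compound 3, at 27200 nM, sits close to compound 2: the data show a 1.1-fold lower number from compound 2 to compound 3 (0.06 log units; within the scatter). Compound 1 stands apart, with a 2.5-fold higher number from compound 1 to compound 3 (0.41 log units; beyond the scatter).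

The next compound is compound 4 `O=C(N/N=C/c1cccc(Cl)c1Cl)Nc1cc2c(Nc3ccc(F)c(Cl)c3)ncnc2cc1O[C@H]1CCOC1`, which has not yet been measured. It carries 2,3-dichlorophenyl in place of 2-chloro-4-fluorophenyl on a carbon with a double bond to nitrogen. The core stays the same.

All three measured steps are swaps at this same place, so they are the best available guide. Besides the two above, there is a 2.9-fold higher number from compound 1 to compound 2 (0.46 log units; beyond the scatter). These swaps have produced modest steps or none beyond the scatter, although three compounds make a thin basis. A modest step in either direction remains possible, but the likeliest outcome is a small one. The expected change is a 1.4-fold lower number from compound 3 to compound 4 (0.13 log units; within the scatter). The estimate for compound 4 is 20000 nM, with an expected range of 9000 nM to 42000 nM.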

Compound 4, half-maximal inhibitory concentration: 25000 nM
The estimate for compound 4 lay 1.3-fold (0.10 log units) below the measured number; the range from low to high includes it.
By their numbers in this assay, from the lowest: compound 1; then compounds 4, 3 and 2 (each within the scatter of the next).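

In this assay the 2,3-dichlorophenyl group of compound 4 falls in with the 2-chloro-4-fluorophenyl and 4-nitrophenyl groups, with a 1.1-fold lower number from compound 3 to compound 4 (0.04 log units; within the scatter) and with a 1.2-fold lower number from compound 2 to compound 4 (0.10 log units; within the scatter). Only the 3-bromophenyl group stands apart, with a 2.3-fold higher number from compound 1 to compound 4 (0.37 log units; beyond the scatter), which leaves compound 1 as the strongest of the four, since its steps to all three others lie beyond the scatter. Nothing measured here gives a reason for this grouping.

The compounds shown leave open how an amine or a carboxylic acid on this phenyl ring would read, since every group here carries only halogen or nitro. Going by these compounds alone, whether the separate place of compound 1 belongs to bromine itself also stays open, as no other compound here carries bromine.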